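Series notes: sulfonamide chain variation on the shared core

A few compounds are considered here, and "the series" means these few. Any claim that something is new, unique, unknown or untested is made for them only; others in the source may bear on it.

Measured so far:
- compound 1, `CCCNS(=O)(=O)c1ccc(Nc2ncc3c(n2)N(C2CCCC2)[C@H](CC)C(=O)N3C)cc1`: 459 nM
- compound 2, `CC[C@@H]1C(=O)N(C)c2cnc(-n3ccc4cc(F)ccc43)nc2N1C1CCCC1`: "not active" (no number reported)
- compound 3, `CCC1C(=O)N(C)c2cnc(-n3ccc4cc(C(N)=O)ccc43)nc2N1c1ccn(C)n1`: 27400 nM

In a functional assay on HeLa cells (Homo sapiens) for antiproliferative activity, read by CCK-8 assay, with a stated time of 72 h (a higher number here means a weaker inhibitor of growth, a lower number a stronger inhibitor of growth), compound 1 gives 459 nM, the lowest of the two numbers available. Compound 3 gives 27400 nM, a gap that lies beyond the scatter; compound 2 returns no single number. Within the data shown here, no pair of compounds here differs in a single place, so no measured step is available within the set.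

Compound 4, `CC[C@@H]1C(=O)N(C)c2cnc(Nc3ccc(S(=O)(=O)NCCO)cc3)nc2N1C1CCCC1`, is to be measured in this assay. It differs from compound 1 as follows: hydroxy in place of methyl on a saturated chain carbon, two bonds along the chain from a sulfonamide nitrogen. The rest of the molecule, including the shared core and the sulfonamide, is unchanged.

With no measured step of this kind in the set, the expectation rests on compound 1 alone, with its 459 nM. The expected step from compound 1 to compound 4 is a 1.1-fold higher number from compound 1 to compound 4 (0.04 log units; within the scatter), no change beyond the scatter in either direction. For compound 4 the estimate is 500 nM, in a range from 200 nM to 1300 nM.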

Compound 4, concentration for 50% growth inhibition: 459 nM
For compound 4 the middle estimate is 1.1-fold (0.04 log units) above the measured one, within the range that was stated.
By their numbers in this assay, from the lowest: compounds 1 and 4 (each within the scatter of the next); then compound 3.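

In this assay there is no change at the digits printed from compound 1 to compound 4 (within the scatter) when hydroxy replaces methyl on a saturated chain carbon, two bonds along the chain from a sulfonamide nitrogen. Among these compounds, this is the first measured step, and it shows that at this chain end, going from propyl to 2-hydroxyethyl adds a hydrogen-bond donor and a hydrogen-bond acceptor without moving the read-out beyond the scatter. No supporting measurement is at hand to explain this outcome.

Among the compounds shown here, the series holds only this one step at the position, so it cannot show whether the same holds for other groups at the chain end, such as an amine or a carboxylic acid. As far as these compounds go, a longer chain on the sulfonamide nitrogen also remains open.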